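The source may report more compounds than this note shows. Statements on the series, on what has been measured and on what is new or still open speak of the compounds shown alone.

Measured in a functional assay on HepG2 cells (Homo sapiens) for antiproliferative activity, read by MTT assay, with a stated time of 48 h; on this read-out higher numbers stand for weaker inhibition of growth and lower numbers for stronger inhibition of growth:
- compound 1 `CCOC(=O)N1N=C(c2ccccc2)CC1c1cc(OC)c(OC)c(OC)c1`: 5950 nM
- compound 2 `CCOC(=O)N1N=C(c2cccc(OC)c2)CC1c1cc(OC)c(OC)c(OC)c1`: 5820 nM

Compound 2, at 5820 nM, stands level with compound 1 within the scatter, so neither leads the pair. Compound 3 `COc1cccc(C2=NN(C(=O)OCc3ccccc3)C(c3cc(OC)c(OC)c(OC)c3)C2)c1` keeps everything in compound 2 except the ester group: phenyl in place of methyl on a saturated chain carbon bound to an oxygen next to a carbonyl group. This is phenyl in place of methyl on a saturated chain carbon bound to an oxygen next to a carbonyl group, or ethoxycarbonyl to benzyloxycarbonyl. Among the compounds with values here, the only measured step, a 1.0-fold lower number from compound 1 to compound 2 (0.01 log units; within the scatter), is methoxy in place of hydrogen on an aromatic carbon. It lies elsewhere on the molecule and stays within the scatter. Within the data shown here, no measured step touches the ethoxycarbonyl group, so the data give no direction in this assay, and no shift beyond the scatter is expected. The expected step is a 1.2-fold lower number from compound 2 to compound 3 (0.07 log units; within the scatter). For compound 3 the estimate is 5000 nM, with an expected range of 1800 nM to 14000 nM.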

Compound 3, concentration for 50% growth inhibition: > 10000 nM
Compound 3: a limit, no number (the forecaster's own chance of this, stated with the estimate: 5%); middle value at least 2.0-fold (0.30 log units) away from the limit.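

In this assay compound 3 reads > 10000 nM, which is a limit of the assay and not a number. Unlike the methoxy change on the aromatic carbon, ethoxycarbonyl to benzyloxycarbonyl touches the ester group, and it gives an at least 1.7-fold higher number from compound 2 to compound 3 (0.23 log units; that floor lies within the scatter). The change therefore shows no gain in growth inhibition at this position, but its full size cannot be read, and only one reading of this kind stands in the series so far: the limit of > 10000 nM in this assay, at which 1 of the 3 values shown sits.

The compounds shown leave open how much of the ester group can change before growth inhibition is lost, for example with a propyl chain in place of the ethyl or a longer chain. They also leave open whether an amine or a carboxylic acid at the end of that chain would give a number below the limit.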